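Dropping a sulfonamide methyl from compound 2

The source may hold more compounds than are shown below. What is called first, only, known or untested is meant among the compounds shown, and "the series" means these compounds.

Compound 1 `CC(C)(C)[C@H]1C(O)=C(C2=NS(=O)(=O)c3c(OCC(N)=O)cccc32)C(=O)N1Cc1ccc(F)c(Cl)c1`: > 1 h
Compound 2 `CN(Cc1cccc2c1S(=O)(=O)C=C2C1=C(O)[C@H](C(C)(C)C)N(CCC(C)(C)C)C1=O)S(C)(=O)=O`: > 1 h

In an in vitro ADME assay on microsomes from liver (Homo sapiens) for metabolic stability (a higher number here means that the compound lasts longer, a lower number that the compound disappears faster), compound 2 gives > 1 h, which is a limit and not a number. Compound 1 gives > 1 h, also a limit. Both compounds therefore stand at the limit of > 1 h in this assay, at which 2 of the 2 values shown sit. Compound 3 `CC(C)(C)CCN1C(=O)C(C2=CS(=O)(=O)c3c(CNS(C)(=O)=O)cccc32)=C(O)[C@@H]1C(C)(C)C` carries hydrogen in place of methyl on a sulfonamide nitrogen. Within the data shown here, no measured step shows what this change does, so no shift beyond the scatter is expected, in either direction. The expected change is a step that the limit leaves unreadable from compound 2 to compound 3. Compound 3 is estimated at 1.2 h, with an expected range of 0.5 h to 2.5 h.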

Compound 3, half-life: > 1 h
Compound 3 was reported as a limit; the forecaster's own chance of this, stated with the estimate: 70%; the middle value does not contradict the limit.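

Compound 2 and compound 3 both stand at a limit, so no step can be read between them: the limit of > 1 h in this assay, at which 3 of the 3 values shown sit.

The compounds shown leave open whether hydrogen in place of methyl on a sulfonamide nitrogen changes the half-life in this assay at all.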